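Ester in place of carbamate on the saturated ring carbon

A few compounds are considered here, and "the series" means these few. Any claim that something is new, unique, unknown or untested is made for them only; others in the source may bear on it.

Compound 1 `CC(C)(C)OC(=O)NC1CCCN(C(=O)CN2CN(c3ccccc3)C3(CCN(C(=O)c4ccc(C5CCCCC5)cc4)CC3)C2=O)C1` gives 4400 nM in an assay on HEK293 cells for displacement of a labelled ligand from NPC1-like intracellular cholesterol transporter 1 (Homo sapiens) (on this read-out higher numbers stand for weaker inhibition and lower numbers for stronger inhibition), and stands second highest of the three numbers recorded so far, nearest to compound 3 `CC(C)(C)OC(=O)NC1CCCN(C(=O)CN2CN(c3ccccc3)C3(CCN(C(=O)c4ccc(C(C)(C)C)cc4)CC3)C2=O)C1` at 4200 nM and furthest from compound 2 `CC(C)(C)c1ccc(C(=O)N2CCC3(CC2)C(=O)N(CC(=O)N2CCC(O)CC2)CN3c2ccccc2)cc1` at 4700 nM, all three within the scatter of one another. Compound 4 `CCOC(=O)C1CCCN(C(=O)CN2CN(c3ccccc3)C3(CCN(C(=O)c4ccc(C5CCCCC5)cc4)CC3)C2=O)C1` differs from compound 1 by ethoxycarbonyl in place of (tert-butoxycarbonyl)amino on a saturated ring carbon. Among the measured compounds shown here, the only measured step in the set, a 1.0-fold lower number from compound 1 to compound 3 (0.02 log units; within the scatter), concerns an aromatic carbon and lies within the scatter, so no measured step bears directly on a change at the saturated ring carbon. For the measured compounds named here, with no relevant step available, no movement beyond the scatter is expected; the change is untested here, so the range is set wide. Compound 4 is therefore expected at 4500 nM in this assay, within 1500 nM to 13000 nM, which amounts to a 1.0-fold higher number from compound 1 to compound 4 (0.01 log units; within the scatter).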

Compound 4, half-maximal inhibitory concentration: 4200 nM
The estimate for compound 4 lay 1.1-fold (0.03 log units) above the measured number; the measured number falls inside the stated range.
By their numbers in this assay, from the lowest: compounds 3, 4, 1 and 2 (each within the scatter of the next).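

At the saturated ring carbon, this assay gives a 1.0-fold lower number from compound 1 to compound 4 (0.02 log units; within the scatter), so this position now has a measured step of its own. The number stays within the scatter when ethoxycarbonyl, with 5 heavy atoms and 0 hydrogen-bond donors, replaces (tert-butoxycarbonyl)amino, with 8 heavy atoms and 1 hydrogen-bond donor. No supporting measurement accounts for this result. Still open, as far as these compounds go, is whether a free amine or a carboxylic acid on this ring carbon would move the number beyond the scatter. Also open, from the compounds shown here alone, is whether ethoxycarbonyl would read the same with tert-butyl in place of cyclohexyl on the aromatic carbon.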